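Thioether series: the step from compound 2 to compound 4

The source may report more compounds than this note shows. Statements on the series, on what has been measured and on what is new or still open speak of the compounds shown alone.

Measured in a functional assay on A-375 cells (Homo sapiens) for inhibition, read by CCK-8 assay, with a stated time of 72 h, tested at 2 uM (a higher number here means more inhibition of growth at the concentration tested, a lower number less inhibition of growth), so far
compound 1 `Nc1ccccc1NC(=O)/C=C/c1ccc(CSc2ccc(Cl)cc2)cc1` gives 13.4%
compound 2 `Nc1ccccc1NC(=O)c1ccc(CSc2cccc(F)c2)cc1` gives 37.7%
compound 3 `COc1ccc(SCc2ccc(C(=O)Nc3ccccc3N)cc2)cc1OC` gives 18.1%

Compound 2 stands highest of the three, beyond the scatter from both others. Compound 4 `Cc1cc(C)cc(SCc2ccc(C(=O)Nc3ccccc3N)cc2)c1` is unmeasured and carries 3,5-dimethylphenyl in place of 3-fluorophenyl on a sulfur with the rest unchanged. Compound 3 also has two groups on the ring at sulfur and gives 18.1% in this assay so a fall is expected rather than a gain. The expected move is a number 11.7 percentage points lower from compound 2 to compound 4 (beyond the scatter) as an estimate, modestly beyond the scatter. The estimated value for compound 4 is 26% within an expected range of 11% to 42% on this thin basis.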

Compound 4, percent growth inhibition at one concentration: 48.5%
Estimate against measurement, compound 4: 22.5 percentage points below; measured number above the stated range.
By their numbers in this assay, from the lowest: compounds 1 and 3 (each within the scatter of the next); then compound 2; then compound 4.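

In this assay, 3,5-dimethylphenyl in place of 3-fluorophenyl on the sulfur gives a number 10.8 percentage points higher from compound 2 to compound 4 (beyond the scatter) in a series where a second ring group had seemed a liability. Compound 3 with two groups on that ring gives 18.1% and compound 4 stands well clear of it, so the count of groups alone does not decide the number. No measurement on hand accounts for the gain.

Still open, as far as these compounds go, is whether the gain depends on both methyl groups or whether a single methyl would match it. An amine or a carboxylic acid on this ring also remains to be placed against compound 4.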